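Solubility notes: shortening the chain on compound 2

The source may report more compounds than this note shows. Statements on the series, on what has been measured and on what is new or still open speak of the compounds shown alone.

compound 1 `Cc1cn2c(N3CC[C@H](N(C)C)C3)c(-c3ccccc3)c(C)c(C#N)c2n1` — 356 ug/mL
compound 2 `CCCCc1nc2c(C#N)c(C)c(-c3ccccc3)c(N3CC[C@H](N(C)C)C3)n2n1` — 33 ug/mL
compound 3 `Cc1c(C(C)(C)C)c(N2CC[C@H](N(C)C)C2)n2nc(C(C)(C)C)nc2c1C#N` — 146 ug/mL

In a physicochemical assay for solubility, at pH 6.8 (on this read-out higher numbers stand for higher solubility and lower numbers for lower solubility), compound 1 gives 356 ug/mL, compound 2 gives 33 ug/mL and compound 3 gives 146 ug/mL. Compound 2 stands lowest of the three numbers; its gap to compound 3 and its wider gap to compound 1 both lie beyond the scatter of repeated measurements. No two of the measured compounds differ in only one place, so none of these gaps can be read as a single step.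

Compound 4 `CCc1nc2c(C#N)c(C)c(-c3ccccc3)c(N3CC[C@H](N(C)C)C3)n2n1` has not yet been measured in this assay. It differs from compound 2 by hydrogen in place of ethyl on a saturated chain carbon, two bonds along the chain from an aromatic carbon. For the measured compounds named here, with no single-place step among the measured compounds to lean on, the expectation rests on compound 2 alone, because its 33 ug/mL is the starting point. The step from compound 2 to compound 4 is expected to be a moderate rise in this assay, probably beyond the scatter, with a 2.4-fold higher number from compound 2 to compound 4 (0.38 log units; beyond the scatter) as the estimated size. Compound 4 is expected to give 80 ug/mL, within a range from 40 ug/mL to 160 ug/mL. The measurement will settle it.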

Compound 4, solubility: 228 ug/mL
Compound 4: middle estimate off by 2.9-fold (0.45 log units), on the low side, outside the stated range (above it).
By their numbers in this assay, from the lowest: compound 2; then compounds 3, 4 and 1 (each within the scatter of the next, the first and the last beyond it).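

For the compounds shown here, the change from butyl to ethyl on this saturated chain gives a 6.9-fold higher number from compound 2 to compound 4 (0.84 log units; beyond the scatter) in this assay and is the only step so far that can be read in one place. It shows that, with the rest of compound 2 held fixed, removing two carbons from this chain is enough to move the read-out beyond the scatter. Nothing available bears on the reason for this step.

The compounds shown leave open how a propyl chain at this place would read, and whether a chain ending in an amine or a carboxylic acid would move the number in the same direction. A single pair also sets no trend with chain length, and it cannot show whether the same step would hold on the core of compound 1.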